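Swapping cyclopentyl for 2-hydroxyethyl on the ring nitrogen

The source may report more compounds than this note shows. Statements on the series, on what has been measured and on what is new or still open speak of the compounds shown alone.

Compound 2 `O=c1c2ccccc2c(-c2cccnc2)nn1C1CCCC1` has the lowest of the two numbers shown in a functional assay (trachea) with Cavia porcellus as the target (a lower number here means a stronger inhibitor, a higher number a weaker inhibitor), where compound 2 gives 2750 nM; its nearest neighbour, compound 1 `CC(C)n1nc(-c2cccnc2)c2ccccc2c1=O`, gives 3090 nM in this assay, within the scatter. Compound 3 `O=c1c2ccccc2c(-c2cccnc2)nn1CCO` differs from compound 2 by 2-hydroxyethyl in place of cyclopentyl on an aromatic nitrogen. Going by the values given here, the only measured step, a 1.1-fold lower number from compound 1 to compound 2 (0.05 log units; within the scatter), exchanged one carbon group for another and stayed within the scatter; it does not directly cover a 2-hydroxyethyl group, so the expectation for compound 3 rests on a wide range. Compound 3 is estimated at 4000 nM, between 1000 nM and 16000 nM, an expected step of a 1.5-fold higher number from compound 2 to compound 3 (0.16 log units; within the scatter).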

Compound 3, half-maximal inhibitory concentration: 4570 nM
Compound 3: the middle estimate sits 1.1-fold (0.06 log units) below what was measured; measured number inside the range.
By their numbers in this assay, from the lowest: compounds 2, 1 and 3 (each within the scatter of the next).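

In this assay, going by these compounds alone, the ring nitrogen took a group containing oxygen for the first time, and the result stayed within the scatter: the change gave a 1.7-fold higher number from compound 2 to compound 3 (0.22 log units; within the scatter), and against the smaller carbon group it gave a 1.5-fold higher number from compound 1 to compound 3 (0.17 log units; within the scatter). So at this position, an open 2-hydroxyethyl chain with one hydrogen-bond donor and one acceptor reads the same in this assay as the carbon-only groups, cyclopentyl and isopropyl. Nothing available accounts for this result. Going by these compounds, what an amine, a carboxylic acid or a longer chain on this nitrogen would give remains open. A plain ethyl group would also be needed to separate the oxygen from the chain.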